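The compounds below may be only part of what the source reports. "The series", "measured", "known", "first", "only" and "open" are said of these compounds alone.

Series notes, sulfonamide set. In a functional assay on CHO cells for inhibition of Orexin receptor type 2 (Homo sapiens), read by FLIPR and calcium flux (on this read-out higher numbers stand for weaker inhibition and lower numbers for stronger inhibition), compound 1 `CCN(CC)C(=O)CN(c1ccc(C)cc1)S(=O)(=O)c1cccc(Cl)c1` gives 139 nM. Compound 2 `CCN(CC)C(=O)CN(c1ccc(C)cc1)S(=O)(=O)c1cccc(C)c1` gives 60 nM in this assay, and compound 3 `CCN(CC)C(=O)CN(c1ccc(C)cc1)S(=O)(=O)c1ccc(C#N)cc1` gives 1190 nM. Compound 3 thus stands highest of the three numbers measured, with compound 1 nearest and compound 2 furthest from it. The steps into compound 3 are both measured: an 8.6-fold higher number from compound 1 to compound 3 (0.93 log units; beyond the scatter), and a 20-fold higher number from compound 2 to compound 3 (1.30 log units; beyond the scatter). The step between the two lower compounds is smaller: a 2.3-fold lower number from compound 1 to compound 2 (0.36 log units; beyond the scatter).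

Compound 4 `CCN(CC)C(=O)CN(c1ccc(C)cc1)S(=O)(=O)c1ccccc1C` is not yet measured. Relative to compound 3 the change is 2-methylphenyl in place of 4-cyanophenyl on a sulfonyl sulfur. The two steps that bear on it are the ones that brought 4-cyanophenyl in, from 3-chlorophenyl and from 3-methylphenyl; compound 4 runs that direction backwards, towards a methylphenyl as in compound 2, but as 2-methylphenyl, for which no measured neighbour exists in this set. How much that placing matters is open. A large step down in this assay is therefore expected, probably short of a full return to the number of compound 2. The estimate for compound 4 is 150 nM, with a range of 40 nM to 600 nM. This means an expected step of a 7.9-fold lower number from compound 3 to compound 4 (0.90 log units; beyond the scatter).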

Compound 4, half-maximal inhibitory concentration: 58 nM
Compound 4: middle estimate off by 2.6-fold (0.41 log units), on the high side; measured number inside the range.
By their numbers in this assay, from the lowest: compounds 4 and 2 (each within the scatter of the next); then compound 1; then compound 3.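

In this assay the placing of the methyl group on the aromatic ring at the sulfonyl sulfur shows no readable effect in this pair: a 1.0-fold lower number from compound 2 to compound 4 (0.01 log units; within the scatter), so 2-methylphenyl and 3-methylphenyl cannot be told apart here. The cost seen with 4-cyanophenyl is now reversed by a second methylphenyl, with a 21-fold lower number from compound 3 to compound 4 (1.31 log units; beyond the scatter), and the lower number relative to the 3-chlorophenyl compound also recurs with the methyl group in its other placing, with a 2.4-fold lower number from compound 1 to compound 4 (0.38 log units; beyond the scatter). Nothing measured in this set offers an explanation for these steps.

Still open, from the compounds shown here alone, is whether the high number of compound 3 goes with the nitrile itself or with its placing, since in this set the nitrile appears only as 4-cyanophenyl and the 4-methylphenyl counterpart is absent from the comparison. Also open, going by these compounds, is how much room this position allows beyond a single methyl group, for instance with an ethyl or methoxy group, or with an amine on the same ring.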